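This account rests on a few compounds, and the source may have more. Where it says the series, first, only, none or still open, it means among the compounds named here.

Measured in a functional assay on MKN-45 cells (Homo sapiens) for cytotoxicity, read by MTT assay, with a stated time of 72 h; on this read-out lower numbers stand for stronger inhibition and higher numbers for weaker inhibition:
- compound 1 `CN(C)CCNc1nc(-c2ccc(NC(=O)Nc3ccc(Cl)cc3)cc2)nc2c(Cl)c(Cl)sc12` gives 910 nM
- compound 2 `Cc1ccc(NC(=O)Nc2ccc(-c3nc(NCCN(C)C)c4sccc4n3)cc2)cc1` gives 2380 nM
- compound 3 `CCN(CC)CCCNc1nc(-c2ccc(NC(=O)Nc3ccccc3)cc2)nc2c(Cl)c(Cl)sc12` gives 1640 nM

Compound 3 stands second highest of the three numbers. Its nearest neighbour is compound 2, whose number is higher by a gap that lies within the scatter; its furthest is compound 1, whose number is lower, again by a gap within the scatter. On these numbers, then, the three compounds cannot be ordered with confidence.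

Compound 4 `CCN(CC)CCCNc1nc(-c2ccc(NC(=O)Nc3ccc(Cl)cc3)cc2)nc2c(Cl)c(Cl)sc12` is the next compound in the series and has not yet been measured in this assay. It differs from compound 3 in one place: chloro in place of hydrogen on an aromatic carbon. Going by the values given here, compound 1 carries this same chloro on its urea phenyl, but it differs from compound 3 in the amine chain as well, so no single step in the data isolates the chloro.

The expectation for compound 4 therefore rests on a loose reading: compound 1, which carries the chloro, sits at a lower number than compound 3, but within the scatter. Compound 4 is expected to show a step of about a 1.6-fold lower number from compound 3 to compound 4 (0.21 log units; within the scatter), toward a lower number, and not beyond the scatter. Compound 4 is estimated at 1000 nM, within a range of 400 nM to 2500 nM.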

Compound 4, half-maximal inhibitory concentration: 720 nM
Compound 4: middle estimate off by 1.4-fold (0.14 log units), on the high side, within the range that was stated.
By their numbers in this assay, from the lowest: compounds 4, 1, 3 and 2 (each within the scatter of the next, the first and the last beyond it).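

In this assay, going by these compounds alone, the exchange of phenyl for 4-chlorophenyl can be read on its own for the first time, with the rest of the molecule held constant, and it gives a 2.3-fold lower number from compound 3 to compound 4 (0.36 log units; beyond the scatter) as a modest step beyond the scatter. Compound 1 and compound 4 share the 4-chlorophenyl group and differ only in the amine chain, with (diethylamino)methyl in place of dimethylamino, and their comparison gives a 1.3-fold lower number from compound 1 to compound 4 (0.10 log units; within the scatter) which stays within the scatter, so the two chains cannot be told apart in this pair. Nothing available accounts for the step seen with the chloro group.

The compounds shown leave open whether fluoro, bromo or methoxy in the same place on the ring would give a step of similar size, and whether the chloro step would appear again with the dimethylamino chain. They also leave open how the number would respond if a cyclic amine such as morpholine or piperidine stood at the end of the chain.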